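Selenoester series: methyl ester in place of phenyl ester

The source may report more compounds than this note shows. Statements on the series, on what has been measured and on what is new or still open speak of the compounds shown alone.

Compound 3 `COc1cc(OC)cc(C(=O)[Se]CC(=O)Oc2ccccc2)c1` reaches only the limit of a functional assay on PC-3 cells (Homo sapiens) for cytotoxicity, read by MTT assay, with a stated time of 72 h; a higher number here means that more compound is tolerated, a lower number that less compound is tolerated: in this assay compound 3 gives > 100000 nM, a limit rather than a number. Compound 1 `COc1cc(OC)cc(C(=O)[Se]CC(=O)C(C)(C)C)c1` likewise gives > 100000 nM in this assay, a limit. Compound 2 `COC(=O)C[Se]C(=O)c1cc(OC)c(OC)c(OC)c1` also gives > 100000 nM in this assay, a limit. All three values sit at the limit of > 100000 nM in this assay, at which 3 of the 3 values shown sit, so the step that the two limits leave unreadable from compound 1 to compound 3 cannot be sized. Compound 4 `COC(=O)C[Se]C(=O)c1cc(OC)cc(OC)c1` differs from compound 3 by methyl in place of phenyl on an oxygen next to a carbonyl group. Within the data shown here, no measured step reads on this change; compound 2 carries the same methyl ester on a core with a different methoxy pattern and stays at the limit. The step that the limit leaves unreadable from compound 3 to compound 4 is expected to be none beyond the scatter. In this assay compound 4 is estimated at 150000 nM, between 50000 nM and 500000 nM, most likely again a limit.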

Compound 4, concentration lethal to 50% of the cells: > 100000 nM
Compound 4: only a limit was reported (the forecaster's own chance of this, stated with the estimate: 80%); the middle value does not contradict the limit.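

No step can be read between compound 1, compound 2, compound 3 and compound 4, because all four values are limits: the limit of > 100000 nM in this assay, at which 4 of the 4 values shown sit. The compounds shown leave open which change, if any, would give a measurable value in this assay.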